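The source may report more compounds than this note shows. Statements on the series, on what has been measured and on what is new or still open speak of the compounds shown alone.

Among the measured compounds shown here, in an ADME assay on L6 cells (Rattus norvegicus) for cytotoxicity (on this read-out higher numbers stand for weaker inhibition and lower numbers for stronger inhibition), only two compounds have numbers so far. Compound 1 (`COc1cc2c(cc1C(C)OCc1ccccc1)C=CC(C)(C)O2`) stands highest at 43900 nM, while compound 2 (`COc1ccc(CNC(C)c2cc3c(cc2OC)OC(C)(C)C=C3)cc1`) gives a clearly lower 14900 nM. The next compound to be tested, compound 3 (`CCNC(C)c1cc2c(cc1OC)OC(C)(C)C=C2`), has ethylamino in place of benzyloxy on a saturated chain carbon bound to an aromatic carbon and a saturated chain carbon. For the measured compounds named here, no measured pair of compounds shows this change on its own, so any expectation for it rests on thin evidence. Going by the values given here, the only guide is the spread between the two measured compounds, with compound 1 at 43900 nM and compound 2 at 14900 nM. A small shift toward a lower number is expected, and the estimated step, a 1.5-fold lower number from compound 1 to compound 3 (0.17 log units; within the scatter), may stay within the usual scatter. Compound 3 is expected to read about 30000 nM in this assay, with an estimated range of 12000 nM to 75000 nM.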

Compound 3, half-maximal inhibitory concentration: 176000 nM
For compound 3 the middle estimate is 5.9-fold (0.77 log units) below the measured one, outside the stated range (above it).
By their numbers in this assay, from the lowest: compound 2; then compound 1; then compound 3.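

In this assay, replacing benzyloxy with ethylamino on this saturated chain carbon gives a 4.0-fold higher number from compound 1 to compound 3 (0.60 log units; beyond the scatter), so the smaller group with an amine nitrogen inhibits more weakly here. Having an amine nitrogen at this place therefore does not by itself bring the number down, as compound 2 and compound 3 both carry one and still read far apart. With methyl in place of 4-methoxyphenyl on the chain carbon bound to that nitrogen, the step is a 12-fold higher number from compound 2 to compound 3 (1.07 log units; beyond the scatter), which shows that the group attached there matters a great deal.

The compounds shown leave open whether a plain benzyl group or a longer chain such as propyl on the amine nitrogen would give a number nearer that of compound 2 or that of compound 3. No measurement shown here accounts for the size or direction of these steps.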